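Aryl methyl position in the biaryl benzyl alcohol series

The compounds below may be only part of what the source reports. "The series", "measured", "known", "first", "only" and "open" are said of these compounds alone.

Measured so far in a functional assay on RKE cells for antagonist activity at Vasoactive intestinal polypeptide receptor 1 (Rattus norvegicus), read by HTRF and cAMP accumulation, with stated times of 10 min and 30 min; on this read-out higher numbers stand for weaker inhibition and lower numbers for stronger inhibition:
Compound 1 `Cc1ccccc1-c1cc(C(C)(C)C)cc(C(C)C)c1CO` gives only a limit, > 50000 nM.
Compound 2 `CC(C)c1cc(C(C)(C)C)cc(-c2cccc(N(C)C)c2)c1CO` gives 310 nM.
Compound 3 `Cc1ccc(-c2cc(C(C)(C)C)cc(C(C)C)c2CO)cc1` gives 300 nM.

Compound 1 stands at the edge of what this assay reports; its value is a limit and not a number (the limit of > 50000 nM in this assay, at which 1 of the 3 values shown sits). Compound 4 `Cc1cccc(-c2cc(C(C)(C)C)cc(C(C)C)c2CO)c1` differs from compound 1 by 3-methylphenyl in place of 2-methylphenyl on an aromatic carbon. Within the data shown here, the one measured step that bears on this change is an at least 160-fold lower number from compound 1 to compound 3 (2.22 log units; beyond the scatter), a large move out of the limit. Compound 2 gives a value close to that of compound 3, the two within the scatter of each other. Compound 4 is therefore expected to land in the same region, estimated at 500 nM with a range of 150 nM to 3000 nM. The expected step is an at least 100-fold lower number from compound 1 to compound 4 (2.00 log units; beyond the scatter).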

Compound 4, half-maximal inhibitory concentration: 240 nM
Compound 4: the middle estimate sits 2.1-fold (0.32 log units) above what was measured; the range from low to high includes it.
By their numbers in this assay, from the lowest: compounds 4, 3 and 2 (each within the scatter of the next). At a limit, above all of these: compound 1.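

3-Methylphenyl in place of 2-methylphenyl gives an at least 200-fold lower number from compound 1 to compound 4 (2.31 log units; beyond the scatter), so among the three methylphenyl compounds shown, only the 2-methylphenyl compound sits out of range. Compound 1 remains a limit and not a number: the limit of > 50000 nM in this assay, at which 1 of the 4 values shown sits. The 3-methylphenyl and 4-methylphenyl compounds are not separated, with a 1.3-fold lower number from compound 3 to compound 4 (0.10 log units; within the scatter), and neither are dimethylamino and methyl on the 3-substituted phenyl, with a 1.3-fold lower number from compound 2 to compound 4 (0.11 log units; within the scatter).

Open, as far as these compounds go, is whether a carboxylic acid or a longer chain in place of the methyl of compound 4 would hold this level.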